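The source may report more compounds than this note shows. Statements on the series, on what has been measured and on what is new or still open speak of the compounds shown alone.

Compound 1 `CCOc1ccc(NC2=CC(=O)c3c(nc4n3[C@H]3OC[C@@H](O)[C@H]3OC4)C2=O)cc1` is one of three compounds tested in a functional assay on MGC-803 cells (Homo sapiens) for inhibition, read by sulforhodamine B assay; a higher number here means a weaker inhibitor, a lower number a stronger inhibitor. In this assay compound 1 gives 2090 nM. Compound 3 `COc1ccc(NC2=CC(=O)c3nc4n(c3C2=O)[C@H]2OC[C@@H](O)[C@H]2OC4)cc1` differs from compound 1 only in carrying a methoxy group where compound 1 carries an ethoxy group, and in this assay compound 3 gives 1680 nM, a value that lies within the usual scatter of the number for compound 1, so the two cannot be told apart. Compound 2 `O=C1C=C(NC2CCCC2)C(=O)c2c1nc1n2[C@H]2OC[C@@H](O)[C@H]2OC1` carries a cyclopentyl group on the amine nitrogen instead of an aromatic ring, and in this assay compound 2 gives > 8000 nM, which is a limit of the assay rather than a number (the limit of > 8000 nM in this assay, at which 1 of the 3 values shown sits). Among the compounds with values here, the single step that can be sized, an at least 4.7-fold lower number from compound 2 to compound 3 (0.67 log units; beyond the scatter), concerns the amine substituent as a whole and not the group on the aromatic ring.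

Compound 4 `O=C1C(Nc2ccc(I)cc2)=CC(=O)c2c1nc1n2[C@H]2OC[C@@H](O)[C@H]2OC1` differs from compound 1 by iodo in place of ethoxy on an aromatic carbon. Within the data shown here, no measured step covers this change; the only pointer is that compound 1 and compound 3, which differ at the same place, sit within the scatter of each other. In this assay compound 4 is therefore expected to give about 1600 nM, with a likely range from 600 nM to 4500 nM. The expected step is a 1.3-fold lower number from compound 1 to compound 4 (0.12 log units; within the scatter), which is not beyond the scatter.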

Compound 4, half-maximal inhibitory concentration: 2150 nM
Compound 4: the middle estimate sits 1.3-fold (0.13 log units) below what was measured, within the range that was stated.
By their numbers in this assay, from the lowest: compounds 3, 1 and 4 (each within the scatter of the next). At a limit, above all of these: compound 2.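

In this assay, replacing the group on the aromatic ring with a very different one leaves the number where it was: a 1.0-fold higher number from compound 1 to compound 4 (0.01 log units; within the scatter). Compound 3 had shown only that methoxy and ethoxy, two oxygen-linked chains, could not be told apart, whereas compound 4 has no oxygen at this position, with iodo bringing 1 heavy atom where ethoxy has 3 and removing the hydrogen-bond acceptor, so for this pair neither that oxygen nor the ethyl chain is needed to keep the number. Nothing measured here gives a reason why these groups cannot be told apart in this assay.

Methoxy, ethoxy and iodo are the only groups shown at this position, so it remains open whether an amine, a carboxylic acid or a longer chain such as butoxy on the same aromatic carbon would also leave the number unchanged. Within the data shown here, compound 2, the only compound here without an aromatic ring on the amine nitrogen, gives a limit and not a number, so the full size of the loss on moving from the aromatic ring to cyclopentyl also remains open.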